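One Methyl on a Triple-Bonded Carbon

This account rests on a few compounds, and the source may have more. Where it says the series, first, only, none or still open, it means among the compounds named here.

Within the data shown here, only two compounds have been measured so far in a functional assay on MIA PaCa-2 cells (Homo sapiens) for antiproliferative activity; on this read-out lower numbers stand for an effect already at smaller amounts and higher numbers for an effect only at larger amounts of compound. Compound 1 (`Cc1cc2c(C(N)=O)cccc2n1-c1nc2c(c(NCc3ccccc3)n1)CCCC2`) gives 128 nM. Compound 2 (`C#CCNC(=O)c1cccc2c1cc(C)n2-c1nc2c(c(NCc3ccccc3)n1)COCC2`) gives 1080 nM, the higher of the two numbers and beyond the scatter from compound 1. These two compounds differ in more than one place, and their gap cannot be assigned to any single change.

Compound 3 (`CC#CCNC(=O)c1cccc2c1cc(C)n2-c1nc2c(c(NCc3ccccc3)n1)COCC2`) has not yet been measured. It departs from compound 2 in one place: methyl in place of hydrogen on a triple-bonded carbon. This is methyl in place of hydrogen on a triple-bonded carbon, which turns propargyl into but-2-yn-1-yl. Among the measured compounds shown here, no measured pair shows what this change does in this assay. The expectation therefore starts from compound 2 at 1080 nM and rests only on how small the structural change is. The expected step is a 1.3-fold lower number from compound 2 to compound 3 (0.10 log units; within the scatter), which is within the scatter and has no firm direction. For compound 3 the estimated value is 850 nM, with an expected range from 300 nM to 2500 nM.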

Compound 3, half-maximal effective concentration: 524 nM
Compound 3: middle estimate off by 1.6-fold (0.21 log units), on the high side, within the range that was stated.
By their numbers in this assay, from the lowest: compound 1; then compound 3; then compound 2.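

In this assay, among these compounds, the change from propargyl to but-2-yn-1-yl gives the first comparison in which only one place differs, and it yields a 2.1-fold lower number from compound 2 to compound 3 (0.31 log units; beyond the scatter) as a modest step. This shows that the triple-bonded carbon at the end of this chain is not a silent position: methyl in place of hydrogen there moves the read-out, and it moves it towards a lower number. Nothing measured alongside this step bears on what lies behind it.

The compounds shown leave open whether the trend continues with an ethyl group or a longer chain on the triple-bonded carbon, or whether a hydroxymethyl group or an amine placed there would take the number the other way. Among the compounds shown here, they also leave open whether the same methyl gives a step of similar size on another core, since compound 1 differs from compound 3 in more than one place and no pair yet tests this change a second time.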